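A few compounds are considered here, and "the series" means these few. Any claim that something is new, unique, unknown or untested is made for them only; others in the source may bear on it.

Measured so far:
compound 1, `Nc1cccc(-c2cn(CC(=O)Nc3nc4ccccc4s3)nn2)c1`, 1110 nM
compound 2, `COc1ccc(-c2cn(CC(=O)Nc3nc(C)cs3)nn2)cc1`, 3890 nM
compound 3, `O=C(Cn1cc(-c2cccc(Cl)c2)nn1)Nc1nccs1`, > 30000 nM

In a functional assay on BMDM cells (Mus musculus, strain C57BL/6) for inhibition, with a stated time of 2 days (a lower number here means a stronger inhibitor, a higher number a weaker inhibitor), compound 1 gives the lowest of the two numbers shown, with compound 2 as its nearest neighbour at a higher value that lies beyond the usual scatter. For compound 3 this assay reports only a limit, (the limit of > 30000 nM in this assay, at which 1 of the 3 values shown sits), and not a number. No two of the measured compounds differ in one place only, so no single change can be followed through a measured pair.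

Compound 4, `O=C(Cn1cc(-c2ccncc2)nn1)Nc1nc2ccccc2s1`, has not yet been measured in this assay. It differs from compound 1 in one place: pyridin-4-yl in place of 3-aminophenyl on an aromatic carbon. The other two measured compounds carry different groups in that place together with further changes on the amide side, so they give no direct reading of this change. The account expects compound 4 to come out somewhat weaker than compound 1, with a step of a 2.7-fold higher number from compound 1 to compound 4 (0.43 log units; beyond the scatter) that is expected to lie beyond the scatter yet well short of the limit. The estimate for compound 4 is 3000 nM, in the range 800 nM to 12000 nM.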

Compound 4, half-maximal inhibitory concentration: 50 nM
Estimate against measurement, compound 4: 60-fold (1.78 log units) above, and the stated range ends above it.
By their numbers in this assay, from the lowest: compound 4; then compound 1; then compound 2. At a limit, above all of these: compound 3.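

In this assay, putting pyridin-4-yl in place of 3-aminophenyl on an aromatic carbon of the five-membered ring gives a 22-fold lower number from compound 1 to compound 4 (1.35 log units; beyond the scatter), a large step beyond the usual scatter. For the compounds shown here, this is the first direct reading at this position: with the rest of the molecule unchanged, the group there alone moves the number strongly, and a six-membered aromatic ring with a hetero atom serves better here than the carbon-only ring bearing an amine. Nothing shown here accounts for the size of this step.

The change removes the amine and brings a ring nitrogen at once, so the pair cannot separate the two; a plain phenyl group would stand between them. As far as these compounds go, whether pyridin-3-yl would match pyridin-4-yl, and whether the step holds with the other amide sides, also remains open.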